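A Methyl Branch on the Carbamate Chain

This account rests on a few compounds, and the source may have more. Where it says the series, first, only, none or still open, it means among the compounds named here.

Compound 1, `CCCOC(=O)Nc1ccc(S(=O)(=O)N2C[C@H](c3ccccc3)NC2=O)cc1CC`: 60 nM
Compound 2, `CCOC(=O)Nc1ccc(S(=O)(=O)N2C[C@H](c3ccccc3)NC2=O)cc1C`: 70 nM

Both compounds were tested in a functional assay on HCT-116 cells (Homo sapiens) for cytotoxicity, read by MTT assay; a higher number here means a weaker inhibitor, a lower number a stronger inhibitor. Compound 1 gives 60 nM, the lowest of the two numbers shown, and compound 2 gives 70 nM; the two numbers lie within the usual scatter of each other, so they cannot be ranked against one another. Compound 3, `CCc1cc(S(=O)(=O)N2C[C@H](c3ccccc3)NC2=O)ccc1NC(=O)OCC(C)C`, has not yet been measured. It differs from compound 1 in one place: methyl in place of hydrogen on a saturated chain carbon bound to two saturated chain carbons. Among the measured compounds shown here, no pair of measured compounds shows this kind of step, so there is nothing in the data to tell how it moves the number. The expectation is that the step from compound 1 to compound 3 stays within the scatter, a 1.2-fold higher number from compound 1 to compound 3 (0.07 log units; within the scatter), neither clearly stronger nor clearly weaker. Compound 3 is therefore estimated at 70 nM, with a range from 30 nM to 160 nM.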

Compound 3, half-maximal inhibitory concentration: 60 nM
The estimate for compound 3 lay 1.2-fold (0.07 log units) above the measured number; the range from low to high includes it.
By their numbers in this assay, from the lowest: compounds 1, 3 and 2 (each within the scatter of the next).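

In this assay, among the compounds shown here, the change from propyl to isobutyl, a methyl in place of hydrogen on a saturated chain carbon bound to two saturated chain carbons, gives no change at the digits printed from compound 1 to compound 3 (within the scatter), the first step here that alters one place only. It shows that this place on the chain can carry a methyl branch with the number staying within the scatter, which compound 1 and compound 2 could not show, since they differ in more than one place. No accompanying measurement explains this result.

As far as these compounds go, whether the chain would hold its number with a larger end, such as a tert-butyl group or a longer chain, or with an amine or a carboxylic acid at its end, remains open. From the compounds shown here alone, the effect of the ethyl group shared by compound 1 and compound 3, taken alone, also remains open.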